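The source may hold more compounds than are shown below. What is called first, only, known or untested is meant among the compounds shown, and "the series" means these compounds.

Measured in an ADME assay on a cell-free system (plasma, Mus musculus) for protein binding:
- compound 1 `CNc1nccc(N2CC[C@H](NC(=O)Nc3ccc(Cl)c(C(F)(F)F)c3)C2)n1`: 99.8%
- compound 2 `O=C(Nc1ccc(Cl)c(C(F)(F)F)c1)N[C@H]1CCN(c2ccncn2)C1`: 99.3%
- compound 3 `CCN1CCN(Cc2ccc(NC(=O)N[C@H]3CCN(c4ccnc(NC)n4)C3)cc2C(F)(F)F)CC1`: not yet measured

In this assay, compound 1 has the lower unbound fraction of the two measured compounds. Compound 3 differs from it by (4-ethylpiperazin-1-yl)methyl in place of chloro on an aromatic carbon. Among the measured compounds shown here, the only measured step, a 3.5-fold higher unbound fraction from compound 1 to compound 2 (0.54 log units; beyond the scatter), replaces methylamino with hydrogen, not the chloro, so it offers only a rough guide to size and none to direction here. A somewhat larger step towards more unbound compound is expected, though the data do not test this change. The expected step is a 5.0-fold higher unbound fraction from compound 1 to compound 3 (0.70 log units; beyond the scatter). Compound 3 is estimated at 99%, with an expected range of 96.5% to 99.7%.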

Compound 3, plasma protein binding: 85.4%
Estimate against measurement, compound 3: 15-fold (1.16 log units) (unbound fraction) below; the whole stated range lies above it.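

In this assay, the aromatic carbon ortho to a trifluoromethyl group is shown for the first time to affect the read-out: (4-ethylpiperazin-1-yl)methyl in place of chloro gives a 73-fold higher unbound fraction from compound 1 to compound 3 (1.86 log units; beyond the scatter). The earlier compounds shown here showed only a change at the methylamino group, a 3.5-fold higher unbound fraction from compound 1 to compound 2 (0.54 log units; beyond the scatter), and said nothing about this carbon. No supporting data bear on what lies behind the new step.

Going by these compounds, whether morpholin-4-ylmethyl or a simple aminomethyl group at this carbon would give a step of similar size remains open. Also open, on these data alone, is whether the step holds with hydrogen in place of methylamino.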